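This account rests on a few compounds, and the source may have more. Where it says the series, first, only, none or still open, it means among the compounds named here.

Compound 1 `O=C(NO)c1ccc(-c2cn([C@H]3C[C@@H](C(=O)O)N(Cc4ccccc4)C3)nn2)cc1` carries its hydroxamic acid on an aromatic ring, and in an assay on Sf9 cells for inhibition of histone deacetylase 11 (Homo sapiens), read by fluorescence, tested at 0.5 uM (a higher number here means more inhibition at the concentration tested (going by the name of the read-out), a lower number less inhibition), compound 1 gives only < 10%, a limit of the assay. Compound 2 `O=C(/C=C/c1cn([C@H]2C[C@H](C(=O)O)N(Cc3ccccc3)C2)nn1)NO` gives 14% in this assay. Compound 3 `O=C(/C=C/c1cn([C@@H]2C[C@H](C(=O)O)N(Cc3ccccc3)C2)nn1)NO` stands at < 10% in this assay, again a limit, so that (the limit of < 10% in this assay, at which 2 of the 3 values shown sit). Among the measured compounds shown here, the one measured step is a number at least 4 percentage points lower from compound 2 to compound 3 (that floor lies within the scatter), and it rests on (the fact that compounds 2 and 3 differ only in the configuration as drawn). Compound 4 `O=C(/C=C/c1cn([C@H]2C[C@@H](C(=O)O)N(Cc3ccccc3)C2)nn1)NO` differs from compound 3 as follows: the two compounds have the same atoms and bonds and differ only in configuration as drawn: 2 of 3 stereo elements differ; a stereocentre at a saturated ring carbon is drawn R in compound 3 and S in compound 4; a stereocentre at a saturated ring carbon is drawn R in compound 3 and S in compound 4. Compound 4 shares one ring configuration with compound 2 and the other with compound 3, and the change from compound 2 to compound 3 stayed within the scatter. Compound 4 is therefore expected to give 9% in this assay, between 0% and 20%. The expected step that the limit leaves unreadable from compound 3 to compound 4 is estimated to lie within the scatter.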

Compound 4, a percentage reported as inhibition, at one concentration (the size of the read-out at that concentration, not a potency): 23%
Beside the measured number, compound 4's estimate is 14 percentage points below it; the whole stated range lies below it.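

In this assay, changing both ring stereocentres together gives a step that can be read, a number at least 13 percentage points higher from compound 3 to compound 4 (beyond the scatter), and configuration alone accounts for it: the fact that compounds 3 and 4 differ only in the configuration as drawn Changing one stereocentre shows no such separation, with a number 9 percentage points higher from compound 2 to compound 4 (within the scatter). Among the compounds shown here, replacing 4-(hydroxycarbamoyl)phenyl with 2-(hydroxycarbamoyl)ethenyl at the same configuration gives a number at least 13 percentage points higher from compound 1 to compound 4 (beyond the scatter); this step and the one from compound 3 both start from a limit of the assay. The compounds shown leave open whether a methyl ester or a primary amide in place of the carboxylic acid would keep the reading of compound 4.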